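Shortening the Linker and Swapping Halogens on a Sulfonamide

A few compounds are considered here, and "the series" means these few. Any claim that something is new, unique, unknown or untested is made for them only; others in the source may bear on it.

Three compounds share a sulfonamide core joined through a saturated chain to a benzylamine. Compound 1 `O=S(=O)(NCCCCNCc1ccc(Br)cc1)c1cc(C(F)(F)F)cc(C(F)(F)F)c1` carries a four-carbon chain and a bis(trifluoromethyl)phenyl sulfonamide; in a functional assay on MIA PaCa-2 cells (Homo sapiens) for inhibition, read by MTT assay, with a stated time of 72 h (a higher number here means a weaker inhibitor of growth, a lower number a stronger inhibitor of growth), compound 1 gives 2100 nM. Compound 3 `O=S(=O)(NCCCCCCNCc1ccc(Br)cc1)c1cc(C(F)(F)F)cc(C(F)(F)F)c1` has a longer chain, and compound 3 gives 2970 nM. Compound 2 `O=S(=O)(NCCCCCCNCc1ccc(Br)cc1)c1ccc(C(F)(F)F)cc1` keeps the longer chain with a single trifluoromethyl group, and compound 2 gives 3830 nM. Compound 1 shows the lowest of the three numbers, but both others lie within the scatter of it, so no ordering can be claimed.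

Compound 4 `O=S(=O)(NCCCNCc1ccc(Cl)c(Cl)c1)c1cc(C(F)(F)F)cc(C(F)(F)F)c1` differs from compound 1 in two ways at once: (3,4-dichlorobenzyl)amino in place of ((4-bromobenzyl)amino)methyl on a saturated chain carbon, three bonds along the chain from a sulfonamide nitrogen

Among the measured compounds shown here, only one measured step speaks to this change. Lengthening the chain gave a 1.4-fold higher number from compound 1 to compound 3 (0.15 log units; within the scatter), which suggests the chain length matters little here. For the measured compounds named here, no measured pair shows what exchanging the bromine for two chlorines does, so that part of the change is unanchored. Compound 4 is therefore expected to stay near compound 1, with a step of a 1.1-fold lower number from compound 1 to compound 4 (0.02 log units; within the scatter), and its estimated value in this assay is 2000 nM, with a plausible range from 800 nM to 5000 nM.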

Compound 4, concentration for 50% growth inhibition: 2700 nM
The estimate for compound 4 lay 1.4-fold (0.13 log units) below the measured number; measured number inside the range.
By their numbers in this assay, from the lowest: compounds 1, 4, 3 and 2 (each within the scatter of the next).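

In this assay, shortening the chain and swapping the halogens on the benzyl ring in a single move gives a 1.3-fold higher number from compound 1 to compound 4 (0.11 log units; within the scatter), so this exchange leaves no readable mark on the number. The earlier compounds shown here varied only the chain and the trifluoromethyl groups, whereas this step also replaces the single bromine on the benzyl ring with two chlorines, and the activity still stays in the same narrow band, although chain and halogens change together here and their separate contributions cannot be told apart. Nothing available here explains this result.

The compounds shown leave open whether the halogens matter at all, since every benzyl ring here carries at least one, and a plain unsubstituted benzyl group or a ring bearing a carboxylic acid would put that to the test. They also leave open how far the amine itself can be altered, for instance by replacing it with an amide, and whether the 3,4-dichlorobenzyl group behaves the same way on a longer chain.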